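A few compounds are considered here, and "the series" means these few. Any claim that something is new, unique, unknown or untested is made for them only; others in the source may bear on it.

Compound 1 `C(#Cc1nc2c(s1)CN(C1CCCCC1)CC2)c1ccccc1` was tested in an assay on HEK293 cells for negative allosteric modulation of metabotropic glutamate receptor 5 (Homo sapiens), read by FLIPR, with a stated time of 1 h; on this read-out lower numbers stand for stronger inhibition and higher numbers for weaker inhibition. In this assay compound 1 gives > 10000 nM, which is a limit of the assay and not a number. Compound 2 `O=C(C1CC(F)(F)C1)N1CCc2nc(C#Cc3cccc(F)c3)sc2C1` is a related compound in this assay, and compound 2 gives > 10000 nM, also a limit. Both values therefore sit at the limit of > 10000 nM in this assay, at which 2 of the 2 values shown sit. Compound 3 `O=S(=O)(C1CC1)N1CCc2nc(C#Cc3ccccc3)sc2C1` has not yet been measured; it differs from compound 1 by cyclopropylsulfonyl in place of cyclohexyl on an amine nitrogen in a ring. For the measured compounds named here, no measured step accompanies this change, so the size of the step is unknown. Compound 3 is expected to land around 8000 nM, with a range from 2000 nM to 30000 nM; the expected step of an at least 1.2-fold lower number from compound 1 to compound 3 (0.09 log units; that floor lies within the scatter) is a guess.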

Compound 3, half-maximal inhibitory concentration: 34 nM
Beside the measured number, compound 3's estimate is 240-fold (2.37 log units) above it; the measured number lies below the stated range.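

On an amine nitrogen in a ring, the choice of group matters greatly: in this assay, cyclopropylsulfonyl in place of cyclohexyl gives an at least 290-fold lower number from compound 1 to compound 3 (2.46 log units; beyond the scatter). Compound 3 thus shows that the shared core can give measurable inhibition when this group sits on that nitrogen. The true size of the step remains unknown, as the value for compound 1 is a limit of the assay: the limit of > 10000 nM in this assay, at which 2 of the 3 values shown sit.

The compounds shown leave open whether the sulfonyl part or the three-membered ring accounts for the step. A methylsulfonyl group or a plain cyclopropyl on the same nitrogen would help to separate the two.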